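Compound 3: bromo in place of fluoro

A few compounds are considered here, and "the series" means these few. Any claim that something is new, unique, unknown or untested is made for them only; others in the source may bear on it.

In a functional assay on MCF7 cells (Homo sapiens) for inhibition, read by MTT assay (a higher number here means a weaker inhibitor, a lower number a stronger inhibitor), compound 1 `COc1cc2ncnc(Nc3ccc(NC(=O)c4cccc(C)c4)cc3)c2cc1OC` gives 13000 nM and compound 2 `COc1cc2ncnc(Nc3ccc(NC(=O)c4ccc(F)cc4)cc3)c2cc1OC` gives 27000 nM. Compound 2 thus has the higher of the two numbers, which makes it the weaker inhibitor of this pair. Compound 3 `COc1cc2ncnc(Nc3ccc(NC(=O)c4ccc(Br)cc4)cc3)c2cc1OC` differs from compound 2 at a single place: bromo in place of fluoro on an aromatic carbon. Bromo takes the place of fluoro on an aromatic carbon, para to a large group. For the measured compounds named here, only one measured step offers any guide: a 2.1-fold higher number from compound 1 to compound 2 (0.32 log units; beyond the scatter). That modest step replaces 3-methylphenyl with 4-fluorophenyl, so it never tests bromo and gives no direction for this change. A small shift is therefore expected, with no clear direction and nothing beyond the scatter, and the expected result is a 1.1-fold lower number from compound 2 to compound 3 (0.03 log units; within the scatter). In this assay, compound 3 is estimated at 25000 nM, with an expected range of 11000 nM to 50000 nM.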

Compound 3, half-maximal inhibitory concentration: 43000 nM
The estimate for compound 3 lay 1.7-fold (0.24 log units) below the measured number, within the range that was stated.
By their numbers in this assay, from the lowest: compound 1; then compounds 2 and 3 (each within the scatter of the next).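

Putting bromo in place of fluoro on this aromatic carbon, para to a large group, gives a 1.6-fold higher number from compound 2 to compound 3 (0.20 log units; within the scatter) in this assay, so these two halogens cannot be told apart here, even though bromo is the larger atom by name alone. Compound 3 also gives a second comparison with the methyl-bearing ring of compound 1, a 3.3-fold higher number from compound 1 to compound 3 (0.52 log units; beyond the scatter), so both 4-halophenyl compounds are weaker inhibitors than compound 1, though each of these steps changes the group and its place together. No measurement shown here accounts for these numbers.

From the compounds shown here alone, whether a group of a different kind at this carbon, such as an amine, a hydroxyl or a carboxylic acid, would move the number beyond the scatter remains open. So does the result for a plain phenyl ring with no added group.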